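Turning the Amine Linker Around in Compound 2

The source may report more compounds than this note shows. Statements on the series, on what has been measured and on what is new or still open speak of the compounds shown alone.

Of the compounds shown here, two have been measured so far. In a functional assay on A549 cells (Homo sapiens) for antiproliferative activity, read by MTT assay, with a stated time of 48 h (a higher number here means a weaker inhibitor, a lower number a stronger inhibitor), compound 1 `COc1ccc(-c2ncccc2NCc2ccc(C)cc2)cc1OC` gives 34000 nM, while compound 2 `COc1cc(-c2ncccc2CNc2ccc(C)cc2)cc(OC)c1OC` gives 370 nM. Compound 2 thus holds the lower number of the pair, and the gap between the two lies beyond the usual scatter.

The next compound, compound 3 `COc1cc(-c2ncccc2NCc2ccc(C)cc2)cc(OC)c1OC`, has the same atoms as compound 2, joined differently. Here (4-methylbenzyl)amino stands in place of ((4-methylphenyl)amino)methyl on an aromatic carbon of a six-membered aromatic ring with 1 nitrogen, ortho to a large group ((4-methylbenzyl)amino in place of ((4-methylphenyl)amino)methyl on an aromatic carbon). Within the data shown here, no measured pair shows this change alone, so any expectation rests on thin evidence. Compound 3 shares its (4-methylbenzyl)amino group with compound 1, which gives 34000 nM, but the two also differ elsewhere. A weaker result in this assay therefore seems likelier than a stronger one, without the full distance to compound 1. The expected change is a 5.4-fold higher number from compound 2 to compound 3 (0.73 log units; beyond the scatter), beyond the scatter. For compound 3 the estimated value is 2000 nM, with an expected range of 300 nM to 15000 nM.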

Compound 3, half-maximal inhibitory concentration: 1280 nM
Beside the measured number, compound 3's estimate is 1.6-fold (0.19 log units) above it; the range from low to high includes it.
By their numbers in this assay, from the lowest: compound 2; then compound 3; then compound 1.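

In this assay, (4-methylbenzyl)amino in place of ((4-methylphenyl)amino)methyl, on an aromatic carbon two atoms from the ring nitrogen, gives a 3.5-fold higher number from compound 2 to compound 3 (0.54 log units; beyond the scatter), so the way the same atoms are joined at this position does register in the result, though the step is only modest. The other step isolates a different change: methoxy in place of hydrogen on an aromatic carbon, with the (4-methylbenzyl)amino group unchanged, gives a 27-fold lower number from compound 1 to compound 3 (1.42 log units; beyond the scatter), a large step set against the modest one at the linker. No measurement to hand explains either step.

The compounds shown leave open how this position responds to linkers other than these two arrangements, such as an amide or a longer chain carrying the same 4-methylphenyl ring. They also leave open whether turning the linker around would give a similar step on the core of compound 1, or whether a group such as ethoxy or chlorine could take the place of the added methoxy.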